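Swapping an Arylethynyl Arm for a Directly Bound Aryl

The source may report more compounds than this note shows. Statements on the series, on what has been measured and on what is new or still open speak of the compounds shown alone.

Compound 1, `CCCCC#Cc1cc([C@@H]2O[C@H](CO)[C@@H](O)[C@H]2O)n2ncnc(N)c12`: 200 nM
Compound 2, `Nc1ncnn2c([C@@H]3O[C@H](CO)[C@@H](O)[C@H]3O)cc(C#Cc3ccc(F)cc3)c12`: 89000 nM
Compound 3, `Nc1ncnn2c([C@@H]3O[C@H](CO)[C@@H](O)[C@H]3O)cc(-c3ccc(Cl)cc3)c12`: 40200 nM

All three were tested in a functional assay on Z-138 cells (Homo sapiens) for antiproliferative activity, with a stated time of 72 h; on this read-out higher numbers stand for weaker inhibition and lower numbers for stronger inhibition. Compound 2 stands highest of the three numbers: the smallest gap is a 2.2-fold lower number from compound 2 to compound 3 (0.35 log units; beyond the scatter), and the largest is a 450-fold higher number from compound 1 to compound 2 (2.65 log units; beyond the scatter). Compound 1, with its hex-1-yn-1-yl group, is the only one of the three that inhibits growth strongly.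

Compound 4, `COc1ccc(-c2cc([C@@H]3O[C@H](CO)[C@@H](O)[C@H]3O)n3ncnc(N)c23)cc1`, is the next step from compound 2. The change is 4-methoxyphenyl in place of 2-(4-fluorophenyl)ethynyl on an aromatic carbon. The step that bears on it most directly is a 2.2-fold lower number from compound 2 to compound 3 (0.35 log units; beyond the scatter), where an aryl ring bound straight to the shared core replaced an arylethynyl arm and the number fell modestly; a 200-fold higher number from compound 1 to compound 3 (2.30 log units; beyond the scatter) shows that such a directly bound aryl ring still sits far above compound 1. Compound 4 is therefore expected to land near compound 3, with a modest lowering from compound 2 of about a 2.2-fold lower number from compound 2 to compound 4 (0.35 log units; beyond the scatter) in this assay. The estimate for compound 4 is 40000 nM, with a range from 12000 nM to 130000 nM.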

Compound 4, half-maximal inhibitory concentration: 62600 nM
Compound 4: middle estimate off by 1.6-fold (0.19 log units), on the low side; the measured number falls inside the stated range.
By their numbers in this assay, from the lowest: compound 1; then compounds 3, 4 and 2 (each within the scatter of the next, the first and the last beyond it).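

In this assay, the 4-methoxyphenyl group of compound 4 cannot be told apart from the 2-(4-fluorophenyl)ethynyl arm (a 1.4-fold lower number from compound 2 to compound 4 (0.15 log units; within the scatter)) or from the directly bound 4-chlorophenyl ring (a 1.6-fold higher number from compound 3 to compound 4 (0.19 log units; within the scatter)). At this aromatic carbon, then, trading chloro for methoxy, which brings in a hydrogen-bond acceptor, does not move the number beyond the usual scatter, and the ring still falls far short of the hex-1-yn-1-yl group (a 310-fold higher number from compound 1 to compound 4 (2.50 log units; beyond the scatter)). No outside evidence bears on this result.

Going by these compounds, whether a shorter or longer chain on the triple bond would keep the strong inhibition of compound 1 stays open. So does whether an amine or a carboxylic acid on the directly bound ring would shift the number at all.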